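Aryl for Alkyl on the Alkyne: Cytotoxicity Outlook

The source may report more compounds than this note shows. Statements on the series, on what has been measured and on what is new or still open speak of the compounds shown alone.

Of the compounds shown here, three sharing one core have been measured in an ADME assay on WI-38 cells (Homo sapiens) for cytotoxicity, read by MTT assay, with a stated time of 3 days; on this read-out higher numbers stand for weaker inhibition and lower numbers for stronger inhibition. Compound 1 `O=C1c2ccccc2C(=O)N1C/C=C\Cn1cc(C#Cc2ccc(Br)cc2)c(=O)[nH]c1=O` gives 47000 nM. Compound 3 `CCCCC#Cc1cn(C/C=C\CN2C(=O)c3ccccc3C2=O)c(=O)[nH]c1=O` gives 28000 nM, and the step of a 1.7-fold lower number from compound 1 to compound 3 (0.22 log units; within the scatter) puts butyl in place of 4-bromophenyl on a triple-bonded carbon. Compound 2 `CCCCCCC#Cc1cn(C/C=C/CN2C(=O)c3ccccc3C2=O)c(=O)[nH]c1=O` gives 40000 nM, a number that sits between those of compound 1 and compound 3 and within the scatter of both.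

Compound 4 `CCCCc1ccc(C#Cc2cn(C/C=C/CN3C(=O)c4ccccc4C3=O)c(=O)[nH]c2=O)cc1` has not yet been measured. It differs from compound 2 in one place: 4-butylphenyl in place of hexyl on a triple-bonded carbon. Among the measured compounds shown here, the only measured step that bears on this exchange is a 1.7-fold lower number from compound 1 to compound 3 (0.22 log units; within the scatter), in which an alkyl chain took the place of an aryl group on the same triple-bonded carbon and the number stayed within the scatter. For the measured compounds named here, the present change runs the other way, from the hexyl chain to an aryl group carrying a butyl chain, and no measured pair covers that exact exchange. On this evidence one expects in this assay no step beyond the scatter for compound 4, and the step of a 1.1-fold higher number from compound 2 to compound 4 (0.05 log units; within the scatter) is estimated to be small. The estimated value for compound 4 is 45000 nM, within a range from 20000 nM to 100000 nM.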

Compound 4, half-maximal inhibitory concentration: 40000 nM
Beside the measured number, compound 4's estimate is 1.1-fold (0.05 log units) above it; measured number inside the range.
By their numbers in this assay, from the lowest: compounds 3, 2, 4 and 1 (each within the scatter of the next).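

In this assay the exchange of hexyl for 4-butylphenyl on a triple-bonded carbon gives no change at the digits printed from compound 2 to compound 4 (within the scatter) and so stays within the scatter, even though a group of 10 heavy atoms with one six-membered aromatic ring of carbon only enters where an open chain of 6 heavy atoms stood. The earlier step, a 1.7-fold lower number from compound 1 to compound 3 (0.22 log units; within the scatter), went from an aryl group to an alkyl chain on compounds with the other arrangement about the double bond of the linker, so the new pair adds a step in the opposite direction, from alkyl to aryl, on the arrangement shared by compound 2 and compound 4, and both steps lie within the scatter. No measurement of any property of these groups accompanies the result, and it offers nothing that would explain it.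

The compounds shown leave open whether this position stays as undemanding when the group on the triple-bonded carbon carries an amine or a carboxylic acid rather than carbon only, or when a longer chain takes the place of the butyl chain. Among the compounds shown here, they also include no pair that differs only in the arrangement about the double bond, so what that arrangement alone does in this assay remains unknown.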